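Notes on the amino-to-bromoacrylamide step at the ring nitrogen

The compounds below may be only part of what the source reports. "The series", "measured", "known", "first", "only" and "open" are said of these compounds alone.

Measured so far:
compound 1, `C=C(Br)C(=O)Nc1cccc(/C=C2\SC(=O)N(Cc3ccc(Cl)cc3)C2=O)c1`: 1600 nM in a functional assay on FM3A cells (Mus musculus) for cytotoxicity, read by cell counting, with a stated time of 2 days; on this read-out higher numbers stand for weaker inhibition and lower numbers for stronger inhibition
compound 2, `Nc1cccc(/C=C2\SC(=O)N(Cc3ccccc3)C2=O)c1`: > 250000 nM in this assay

Compound 2 stands at the limit of this assay, (the limit of > 250000 nM in this assay, at which 1 of the 2 values shown sits); no number is known for it, only that it sits at that limit. Within the data shown here, compound 1 differs from compound 2 in two places, so no single step joins them; the two values show only that compound 1 gives a number while compound 2 gives a limit.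

Compound 3, `C=C(Br)C(=O)Nc1cccc(/C=C2\SC(=O)N(Cc3ccccc3)C2=O)c1`, is not yet measured. It differs from compound 2 by (1-bromoethenyl)carbonyl in place of hydrogen on a nitrogen on an aromatic ring. The step from compound 2 to compound 3 is expected to be large and toward stronger inhibition, well beyond the scatter of this assay: an at least 100-fold lower number from compound 2 to compound 3 (2.00 log units; beyond the scatter). For compound 3 the estimate in this assay is 2500 nM, with a range of 500 nM to 15000 nM. This expectation rests on compound 1, which carries the same acyl group on the ring nitrogen and gives 1600 nM in this assay.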

Compound 3, half-maximal inhibitory concentration: 810 nM
Compound 3: the middle estimate sits 3.1-fold (0.49 log units) above what was measured; the measured number falls inside the stated range.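

With (1-bromoethenyl)carbonyl in place of hydrogen on a nitrogen on an aromatic ring, this assay now gives a step that changes one place only: an at least 300-fold lower number from compound 2 to compound 3 (2.48 log units; beyond the scatter). As far as these compounds go, compound 2 remains a limit and not a number, so the true size of this step stays unknown and the step can be read only as a bound: the limit of > 250000 nM in this assay, at which 1 of the 3 values shown sits. The second step, hydrogen in place of chloro on an aromatic carbon, gives a 2.0-fold lower number from compound 1 to compound 3 (0.30 log units; within the scatter), which lies within the scatter, so this assay does not separate the two compounds that carry the same acyl group on the ring nitrogen.

The compounds shown do not tell whether the large step belongs to the amide as such or to the bromine on the ethenyl part, a question that a plain acetyl group or an acryloyl group without bromine on the same nitrogen could address. Also open, from the compounds shown here alone, is whether the result at the chloro place holds for other groups on that aromatic carbon, such as methoxy or a carboxylic acid.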